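Lengthening the amide chain by one more carbon

This account rests on a few compounds, and the source may have more. Where it says the series, first, only, none or still open, it means among the compounds named here.

Three compounds share one core and differ only in the length of the chain attached to the amide carbonyl. Compound 1 `COc1ccc(CCCCNC(C)=O)cc1` gives 7300 nM in an assay for binding affinity to melatonin receptor (Gallus gallus); a lower number here means a stronger inhibitor, a higher number a weaker inhibitor. Compound 2 `CCC(=O)NCCCCc1ccc(OC)cc1` gives 1400 nM, and compound 3 `CCCC(=O)NCCCCc1ccc(OC)cc1` gives 822 nM. Compound 3 holds the lowest number of the three, though its gap to compound 2 stays within the scatter, so those two cannot be ordered. The steps show this: a 5.2-fold lower number from compound 1 to compound 2 (0.72 log units; beyond the scatter) and an 8.9-fold lower number from compound 1 to compound 3 (0.95 log units; beyond the scatter) are both beyond the scatter, whereas a 1.7-fold lower number from compound 2 to compound 3 (0.23 log units; within the scatter) is not.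

Compound 4 `CCCCC(=O)NCCCCc1ccc(OC)cc1` has not been measured. It differs from compound 3 as follows: methyl in place of hydrogen on a saturated chain carbon, three bonds along the chain from a carbonyl carbon. Within the data shown here, the only guide is a 1.7-fold lower number from compound 2 to compound 3 (0.23 log units; within the scatter), the same kind of addition made two bonds along the chain from a carbonyl carbon, which stayed within the scatter. A change of similar or smaller size is therefore expected, and no step beyond the scatter is anticipated: a 1.4-fold lower number from compound 3 to compound 4 (0.14 log units; within the scatter). Compound 4 is expected to give about 600 nM, with a likely range from 250 nM to 1500 nM.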

Compound 4, inhibition constant: 7000 nM
Compound 4: middle estimate off by 12-fold (1.07 log units), on the low side; the measured number lies above the stated range.
By their numbers in this assay, from the lowest: compounds 3 and 2 (each within the scatter of the next); then compounds 4 and 1 (each within the scatter of the next).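

Adding a methyl three bonds along the chain from a carbonyl carbon gives an 8.5-fold higher number from compound 3 to compound 4 (0.93 log units; beyond the scatter), so in this assay lengthening the chain does not keep lowering the number, and this position is not one where a further carbon goes unnoticed. Measured from the shorter chains, ethyl in place of hydrogen two bonds along the chain from a carbonyl carbon gives a 5.0-fold higher number from compound 2 to compound 4 (0.70 log units; beyond the scatter), while the step from the shortest chain is a 1.0-fold lower number from compound 1 to compound 4 (0.02 log units; within the scatter), which leaves compound 4 level with compound 1. The same added carbons lower the number on the shorter chains and raise it on this one: the same change on two cores in this assay, a 5.2-fold lower number (0.72 log units; beyond the scatter) from compound 1 to compound 2 and an 8.5-fold higher number (0.93 log units; beyond the scatter) from compound 3 to compound 4, 44-fold (1.65 log units) apart, beyond the scatter of two such steps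

The compounds shown leave open whether a still longer chain would raise the number further or level off. They also leave open what a branched isopropyl or a cyclopropyl ring would give in place of this straight chain, and why the number rises here.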